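Swapping a phenyl for a pyridine on the piperazine

A few compounds are considered here, and "the series" means these few. Any claim that something is new, unique, unknown or untested is made for them only; others in the source may bear on it.

Measured so far:
compound 1 `OCc1ccc(N2CCN(CCC(O)c3ccc(Cl)cc3)CC2)cc1Cl`: 11 nM
compound 2 `Cc1ccc(N2CCN(CCC3NC(=O)c4ccccc43)CC2)cc1`: 12.4 nM

Both numbers come from an assay on CHO cells for binding affinity to D(4) dopamine receptor (Homo sapiens); on this read-out higher numbers stand for weaker inhibition and lower numbers for stronger inhibition. In this assay compound 1 gives 11 nM and compound 2 gives 12.4 nM. Compound 2 carries the higher of the two numbers, but the gap to compound 1 is far inside the usual scatter of repeated measurements, so the two cannot be told apart on these data.

The next compound, compound 3 `Cc1ccnc(N2CCN(CCC3NC(=O)c4ccccc43)CC2)c1`, has not yet been measured. It differs from compound 2 in one place: 4-methylpyridin-2-yl in place of 4-methylphenyl on an amine nitrogen in a ring. The rest of the molecule, the piperazine with its chain and the bicyclic amide, is unchanged.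

For the measured compounds named here, no measured pair shows what this kind of exchange does here, so the expectation rests on the single point of compound 2. The change is small in size, and a step of modest extent, if any, is expected, with a slight lean toward a higher number rather than a lower one. Compound 3 is expected to give 20 nM, within a range from 6 nM to 70 nM. That estimate means an expected step of a 1.6-fold higher number from compound 2 to compound 3 (0.21 log units; within the scatter), one that may well stay within the scatter.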

Compound 3, inhibition constant: 22.6 nM
Beside the measured number, compound 3's estimate is 1.1-fold (0.05 log units) below it; the range from low to high includes it.
By their numbers in this assay, from the lowest: compounds 1, 2 and 3 (each within the scatter of the next, the first and the last beyond it).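

In this assay, the exchange of 4-methylphenyl for 4-methylpyridin-2-yl on the amine nitrogen in the ring gives a 1.8-fold higher number from compound 2 to compound 3 (0.26 log units; within the scatter), so compound 2 and compound 3 cannot be told apart on these data. For the compounds shown here, this is the first measured pair at this place, and it shows that one carbon of the aromatic ring can be exchanged for a nitrogen, which adds one hydrogen-bond acceptor to the count and leaves the heavy-atom count at 7, without a step that stands clear of the scatter. No measurement is available that would explain this outcome or show what the added nitrogen does here.

Going by these compounds alone, this single pair covers only one exchange in one molecular setting, so it remains open whether the same exchange would give a similarly small step with the other side of the molecule altered, for instance with the side chain of compound 1. It also leaves open how this assay would respond to other groups at the same place, such as a 4-methoxyphenyl group, a 4-chlorophenyl group or a pyrimidine ring.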